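The compounds below may be only part of what the source reports. "The series", "measured", "known", "first", "only" and "open" are said of these compounds alone.

Measured so far:
compound 1 `OC[C@H]1O[C@@H](n2cnc3c(NCc4ccccc4Cl)ncnc32)[C@H](O)[C@@H]1O` — > 166000 nM
compound 2 `COc1cccc(CNc2ncnc3c2ncn3[C@@H]2O[C@H](CO)[C@@H](O)[C@H]2O)c1` — > 166000 nM
compound 3 `OC[C@H]1O[C@@H](n2cnc3c(NCc4ccc(F)c(Cl)c4)ncnc32)[C@H](O)[C@@H]1O` — > 166000 nM

In a functional assay on MCF cells (Homo sapiens) for antiproliferative activity, with a stated time of 72 h (on this read-out lower numbers stand for stronger inhibition and higher numbers for weaker inhibition), compound 1 gives only a limit of the assay, > 166000 nM. In this assay compound 2 likewise gives only a limit, > 166000 nM. For compound 3 this assay again reports only a limit, > 166000 nM. All three values therefore sit at the limit of > 166000 nM in this assay, at which 3 of the 3 values shown sit, and none of the steps among them can be read: a step that the two limits leave unreadable from compound 1 to compound 2, a step that the two limits leave unreadable from compound 1 to compound 3, a step that the two limits leave unreadable from compound 2 to compound 3. Compound 3 thus stands on no number at all, only on a limit shared with the other two.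

Compound 4 `OC[C@H]1O[C@@H](n2cnc3c(NCc4cccc(O)c4O)ncnc32)[C@H](O)[C@@H]1O` has not yet been measured in this assay. The change from compound 3 is 2,3-dihydroxyphenyl in place of 3-chloro-4-fluorophenyl on a saturated chain carbon bound to a nitrogen on an aromatic ring. Going by the values given here, no measured step bears on this change with a readable size; the three steps that exist are all unreadable from their limits, so they give no direction.

The expectation is that compound 4 stays where compound 3 sits, most likely as a limit again, so the estimate is 200000 nM, with a range from 50000 nM to 800000 nM. The step from compound 3 to compound 4 is therefore expected to be a step that the limit leaves unreadable from compound 3 to compound 4, which cannot be told apart from none.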

Compound 4, half-maximal inhibitory concentration: 5200 nM
Compound 4: the middle estimate sits 38-fold (1.59 log units) above what was measured; the whole stated range lies above it.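

In this assay, the group on a saturated chain carbon bound to a nitrogen on an aromatic ring proves able to bring the read-out off the limit: 2,3-dihydroxyphenyl in place of 3-chloro-4-fluorophenyl gives an at least 31-fold lower number from compound 3 to compound 4 (1.50 log units; beyond the scatter). The same group gives an at least 31-fold lower number from compound 2 to compound 4 (1.50 log units; beyond the scatter) in place of 3-methoxyphenyl and an at least 31-fold lower number from compound 1 to compound 4 (1.50 log units; beyond the scatter) in place of 2-chlorophenyl, so all three replaced rings, chlorinated or methoxylated, stand on the same side of the new compound, and each of these steps starts from a limit. The earlier compounds could not show that this position responds at all, and the steps among them cannot be read: the limit of > 166000 nM in this assay, at which 3 of the 4 values shown sit.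

Going by these compounds alone, compound 4 is the only compound here with a readable value, so the full size of each step stays open, as does the question of whether the change depends on both hydroxyl groups. Nor do the compounds shown tell whether a phenyl with a single hydroxyl, a phenyl with two methoxy groups or a phenyl carrying an amine at this position would also come off the limit.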